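Hydrogen for benzoyl on the amide-type nitrogen: cytotoxicity

The source may hold more compounds than are shown below. What is called first, only, known or untested is meant among the compounds shown, and "the series" means these compounds.

Working notes on the series. Compound 1 `Cc1ccc(/C=N/N(C(=O)c2ccccc2)C(=O)c2ccncc2)cc1` and compound 2 `CSc1ccc(/C=N/N(C(=O)c2ccccc2)C(=O)c2ccncc2)cc1` share one core; compound 3 `O=C(N/N=C/c1c[nH]c2ccccc12)c1ccncc1` already carries hydrogen on the amide-type nitrogen. In an ADME assay on Vero cells (Chlorocebus sabaeus) for cytotoxicity (on this read-out higher numbers stand for lower toxicity in this test and lower numbers for higher toxicity in this test), compound 1 gives >= 20 ug/mL, which is a limit of the assay and not a number. Compound 2 stands at >= 100 ug/mL in this assay, likewise a limit. Compound 3 reaches > 100 ug/mL in this assay, again a limit. Going by the values given here, since every value shown is a limit, the one measured step has no readable size: a step that the two limits leave unreadable from compound 1 to compound 2.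

The change to compound 4 `CSc1ccc(/C=N/NC(=O)c2ccncc2)cc1` is hydrogen in place of benzoyl on an amide-type nitrogen. Among the compounds with values here, no measured step bears directly on this exchange, and the only step recorded is unreadable. The value of compound 3 shows that a member with hydrogen on that nitrogen also sits at a limit in this assay. For compound 4 the expected result is again a limit, estimated at 150 ug/mL with a range from 50 ug/mL to 400 ug/mL. The expected step that the limit leaves unreadable from compound 2 to compound 4 is therefore none beyond the scatter.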

Compound 4, minimum cytotoxic concentration: >= 100 ug/mL
Compound 4: only a limit was reported; the forecaster's own chance of this, stated with the estimate: 85%; the middle value lies beyond the limit too.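

In this assay no new step can be read from compound 2 to compound 4, as both values are limits and not numbers: the limit of >= 100 ug/mL in this assay, at which 2 of the 4 values shown sit. The compounds shown leave open whether hydrogen in place of benzoyl on the amide-type nitrogen changes cytotoxicity at all, and by how much.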